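A few compounds are considered here, and "the series" means these few. Any claim that something is new, unique, unknown or untested is made for them only; others in the source may bear on it.

For the measured compounds named here, compound 1 `O=C(NO)c1ccc(/C=C/c2ccnc(-c3cccc(O)c3)c2)cc1` stands with the lowest of the two numbers so far: in an assay on isolated protein for inhibition of protein deacetylase HDAC6 (Homo sapiens), read by fluorescence, with a stated time of 15 min (a lower number here means a stronger inhibitor, a higher number a weaker inhibitor), compound 1 gives 19 nM. Its nearest neighbour, compound 2 `O=C(NO)c1ccc(/C=C/c2cccc(-c3cc(F)ccc3O)c2)cc1`, is a weaker inhibitor in this assay, where compound 2 gives 240 nM, a gap beyond the scatter. Compound 3 `O=C(NO)c1ccc(/C=C/c2ccncc2)cc1` differs from compound 1 in one place: hydrogen in place of 3-hydroxyphenyl on an aromatic carbon. Going by the values given here, no step between measured compounds matches this change. With the cap reduced to a bare hydrogen, a modest loss in this assay is expected, a 3.2-fold higher number from compound 1 to compound 3 (0.50 log units; beyond the scatter). Compound 3 is therefore estimated at 60 nM, with a range from 20 nM to 200 nM.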

Compound 3, half-maximal inhibitory concentration: 130 nM
Compound 3: the middle estimate sits 2.2-fold (0.34 log units) below what was measured, and the stated range covers the measured number.
By their numbers in this assay, from the lowest: compound 1; then compounds 3 and 2 (each within the scatter of the next).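

Replacing the 3-hydroxyphenyl with hydrogen on this aromatic carbon, next to the ring nitrogen, gives a direct reading of that group in this assay and shows a 6.8-fold higher number from compound 1 to compound 3 (0.84 log units; beyond the scatter) as a modest loss. With only hydrogen at this position, compound 3 still gives 130 nM in this assay, so the 3-hydroxyphenyl is not required for inhibition here. The compounds shown leave open whether the hydroxyl or the phenyl ring accounts for the step, and whether an unsubstituted phenyl, a methoxyphenyl or an amine here would recover it. No measurement shown gives a reason for the step.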